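Cyano for Bromo: Cytotoxicity Expected to Remain Unmeasurable

A few compounds are considered here, and "the series" means these few. Any claim that something is new, unique, unknown or untested is made for them only; others in the source may bear on it.

Compound 2 `O=[N+]([O-])c1ccc(CN2CCC(n3cc(CC(OCc4cc(-c5cccc(Br)c5)no4)c4ccc(Br)cc4)nn3)CC2)cc1` shows only a limit in an ADME assay on cells (Fibroblast, Homo sapiens) for cytotoxicity, with a stated time of 48 h (on this read-out higher numbers stand for weaker inhibition and lower numbers for stronger inhibition), where compound 2 gives > 25000 nM. Compound 1 `COc1ccc(-c2cc(COC(Cc3cn(C4CCN(Cc5ccc([N+](=O)[O-])cc5)CC4)nn3)c3ccc(Br)cc3)on2)cc1` likewise stops at a limit; in this assay compound 1 gives > 25000 nM. The one measured step, a step that the two limits leave unreadable from compound 1 to compound 2, has no readable size, a point shown by the limit of > 25000 nM in this assay, at which 2 of the 2 values shown sit. Compound 3 `N#Cc1cccc(-c2cc(COC(Cc3cn(C4CCN(Cc5ccc([N+](=O)[O-])cc5)CC4)nn3)c3ccc(Br)cc3)on2)c1` carries cyano in place of bromo on an aromatic carbon. Because both measured values sit at the same limit (the limit of > 25000 nM in this assay, at which 2 of the 2 values shown sit), no direction can be expected. Compound 3 is therefore expected to remain at that limit, a step that the limit leaves unreadable from compound 2 to compound 3. Compound 3 is estimated at 30000 nM in this assay, between 10000 nM and 100000 nM.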

Compound 3, half-maximal inhibitory concentration: > 25000 nM
Compound 3: a limit, no number; the forecaster's own chance of this, stated with the estimate: 80%; the middle value does not contradict the limit.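

No step can be read between compound 1, compound 2 and compound 3, as each result is only a limit: the limit of > 25000 nM in this assay, at which 3 of the 3 values shown sit.

In this assay the compounds shown leave open whether the 4-methoxyphenyl, 3-bromophenyl and 3-cyanophenyl versions differ at all.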